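Fluoro-to-hydrogen step carried into a second core

This account rests on a few compounds, and the source may have more. Where it says the series, first, only, none or still open, it means among the compounds named here.

In a physicochemical assay for solubility, read by HPLC, using the shake flask method, in phosphate buffer, measured as kinetic solubility, with a stated time of 20 h, at pH 6.5; on this read-out lower numbers stand for lower solubility and higher numbers for higher solubility:
compound 1 `Fc1ccc(Nc2cc3[nH]c(Nc4ccc(N5CCN(CC6CC6)CC5)cn4)nc3cn2)cc1C(F)(F)F` gives 75000 nM
compound 2 `FC(F)(F)c1cccc(Nc2cc3[nH]c(Nc4ccc(N5CCN(CC6CC6)CC5)cn4)nc3cn2)c1` gives 130000 nM
compound 3 `C[C@@H]1CN(C(=O)c2ccnc(Nc3nc4cnc(Nc5ccc(F)c(C(F)(F)F)c5)cc4[nH]3)c2)C[C@H](C)N1` gives 200000 nM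

Within the first core the single measured change is hydrogen in place of fluoro on an aromatic carbon, and it produced a 1.7-fold higher number from compound 1 to compound 2 (0.24 log units; within the scatter). Compound 3 carries a different core; how its core differs from the core of compound 1 is not broken down here. In this assay compound 3 gives 200000 nM, a higher number than compound 1 with 75000 nM, while compound 2 and compound 3 lie within the scatter of each other.

Compound 4 `C[C@@H]1CN(C(=O)c2ccnc(Nc3nc4cnc(Nc5cccc(C(F)(F)F)c5)cc4[nH]3)c2)C[C@H](C)N1` differs from compound 3 by hydrogen in place of fluoro on an aromatic carbon, the same change as between compound 1 and compound 2, at a place described in the same words. The step is expected to be a 1.5-fold higher number from compound 3 to compound 4 (0.18 log units; within the scatter), resting on a 1.7-fold higher number from compound 1 to compound 2 (0.24 log units; within the scatter). Compound 4 is estimated at 300000 nM, between 150000 nM and 600000 nM.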

Compound 4, solubility: 200000 nM
For compound 4 the middle estimate is 1.5-fold (0.18 log units) above the measured one; the range from low to high includes it.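

In this assay the change from fluoro to hydrogen gives no change at the digits printed from compound 3 to compound 4 (within the scatter), and in the first core the same change gave a 1.7-fold higher number from compound 1 to compound 2 (0.24 log units; within the scatter), so in both cores the step stays within the scatter. These two pairs show no readable shift from this change in either core, but they do not show that the change is without effect, that its size is the same in both cores, or that it would behave alike in a third core. No measurement available here bears on why the numbers fall as they do.

Still open, from the compounds shown here alone, is whether a chloro, methoxy or nitrile group in place of the fluoro would give a step beyond the scatter in either core. Also open, going by these compounds, is how the read-out would respond to an amine or a carboxylic acid in place of the trifluoromethyl group.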